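One Aryl Swap on Compound 1 Toward Compound 3

The compounds below may be only part of what the source reports. "The series", "measured", "known", "first", "only" and "open" are said of these compounds alone.

Compound 1: `CCCc1nc(-c2ccccc2)c(CNCCN2CCN(c3cccc(C(F)(F)F)c3)CC2)o1`, 56.3%
Compound 2: `CCCc1nc(-c2ccccc2)c(CNCCCN2CCN(c3ccc(OC)cc3)CC2)o1`, 42.1%

In an assay on HEK293 cells for inhibition of Voltage-dependent T-type calcium channel subunit alpha-1G (Homo sapiens), read by fluorescence, tested at 10 uM (on this read-out lower numbers stand for less inhibition and higher numbers for more inhibition at the one concentration tested (going by the name of the read-out)), compound 1 stands highest of the two numbers; compound 2 sits lower by a gap beyond the usual scatter. Compound 3, `CCCc1nc(-c2ccccc2)c(CNCCN2CCN(c3ccc(C)cc3)CC2)o1`, is not yet measured in this assay. It differs from compound 1 in one place: 4-methylphenyl in place of 3-(trifluoromethyl)phenyl on an amine nitrogen in a ring. No step of this kind has been measured among these compounds, so its size is uncertain; a modest fall in this assay is expected, about a number 11.3 percentage points lower from compound 1 to compound 3 (beyond the scatter). For compound 3 the estimated value is 45%, expected to lie between 25% and 65%.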

Compound 3, a percentage reported as inhibition, at one concentration (the size of the read-out at that concentration, not a potency): 48.1%
Compound 3: middle estimate off by 3.1 percentage points, on the low side; measured number inside the range.
By their numbers in this assay, from the lowest: compounds 2, 3 and 1 (each within the scatter of the next, the first and the last beyond it).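

In this assay the step of a number 8.2 percentage points lower from compound 1 to compound 3 (within the scatter) is the first one-place comparison among these compounds. It shows that, on an amine nitrogen in a ring, 4-methylphenyl can stand in place of 3-(trifluoromethyl)phenyl with no difference that can be told from the usual scatter. Nothing measured here explains this result. Still open, going by these compounds, is whether a plain phenyl or a pyridine ring at this place would give a similar number. On these data alone, the same swap on the longer chain of compound 2 also remains open.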